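Amine replacement on the propoxy chain of compound 2

This account rests on a few compounds, and the source may have more. Where it says the series, first, only, none or still open, it means among the compounds named here.

Measured so far:
Compound 1 `COc1cc2c(Oc3ccc(NC(=O)c4cn(-c5ccccc5Cl)nn4)cc3F)ccnc2cc1OCCCN1CCCC1` gives 330 nM in a functional assay on A549 cells (Homo sapiens) for cytotoxicity, read by MTT assay, with a stated time of 72 h; a lower number here means a stronger inhibitor, a higher number a weaker inhibitor.
Compound 2 `COc1cc2c(Oc3ccc(NC(=O)c4cn(-c5ccccc5C)nn4)cc3F)ccnc2cc1OCCCN1CCCC1` gives 900 nM in this assay.
Compound 3 `COc1cc2c(Oc3ccc(NC(=O)c4cn(-c5c(C)cccc5C)nn4)cc3F)ccnc2cc1OCCCN1CCCC1` gives 1240 nM in this assay.

Compound 2 stands second highest of the three numbers. Its nearest neighbour is compound 3, and the step of a 1.4-fold higher number from compound 2 to compound 3 (0.14 log units; within the scatter) lies within the scatter. Its furthest neighbour is compound 1, and the step of a 2.7-fold higher number from compound 1 to compound 2 (0.44 log units; beyond the scatter) lies beyond the scatter, as does a 3.8-fold higher number from compound 1 to compound 3 (0.57 log units; beyond the scatter). All three steps alter the aryl group on the aromatic nitrogen while the rest of the shared core is unchanged.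

Compound 4 `COc1cc2c(Oc3ccc(NC(=O)c4cn(-c5ccccc5C)nn4)cc3F)ccnc2cc1OCCCN1CCN(C)CC1` differs from compound 2 in one place: 4-methylpiperazin-1-yl in place of pyrrolidin-1-yl on a saturated chain carbon, three bonds along the chain from an oxygen on an aromatic ring. Among the measured compounds shown here, none of the measured steps bears on this part of the structure; in every measured pair the group on the saturated chain carbon three bonds along the chain from the oxygen on the aromatic ring is the same. The series gives no direct guide to this change, so no step beyond the scatter is assumed in this assay. Compound 4 is expected to give 900 nM, with a range of 400 nM to 2000 nM. This expectation amounts to no change at the digits printed from compound 2 to compound 4 (within the scatter), a step within the scatter.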

Compound 4, half-maximal inhibitory concentration: 3100 nM
The estimate for compound 4 lay 3.4-fold (0.54 log units) below the measured number; the measured number lies above the stated range.
By their numbers in this assay, from the lowest: compound 1; then compounds 2 and 3 (each within the scatter of the next); then compound 4.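

Notes on the amine end of the chain: in this assay, the group on the saturated chain carbon, three bonds along the chain from an oxygen on an aromatic ring, is not neutral to the read-out, since 4-methylpiperazin-1-yl in place of pyrrolidin-1-yl gives a 3.4-fold higher number from compound 2 to compound 4 (0.54 log units; beyond the scatter). Among the compounds shown here, compounds 1, 2 and 3 all carry pyrrolidin-1-yl, so they showed only the effect of the aryl group on the aromatic nitrogen; this pair is the first indication that the number also moves at this separate site, and here it moves upward with the six-membered ring. No available measurement accounts for this step.

One pair cannot separate the enlarged ring from the added ring nitrogen or its methyl group, so piperidin-1-yl, morpholin-4-yl and piperazin-1-yl without the methyl remain the informative comparisons at this position, alongside an open-chain dimethylamino group or a longer chain. As far as these compounds go, whether the same change has a similar effect with the 2-chlorophenyl group of compound 1 or the 2,6-dimethylphenyl group of compound 3 also remains open.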